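The compounds below may be only part of what the source reports. "The series", "measured", "known", "first", "only" and "open" are said of these compounds alone.

Measured so far:
compound 1 `Fc1cccc(N2CCN(CCCOc3ccc4c(c3)CCC4)CC2)c1`: 42%
compound 2 `Clc1cc(Cl)cc(N2CCN(CCCOc3ccc4c(c3)CCC4)CC2)c1`: 0%
compound 3 `FC(F)(F)c1cccc(N2CCN(CCCCCOc3ccc4c(c3)CCC4)CC2)c1`: 66%

In a functional assay on the whole organism for inhibition, with Mus musculus as the target, at a dose of 25 mg/kg by the oral route (on this read-out higher numbers stand for more inhibition at the one dose given (going by the name of the read-out) and lower numbers for less inhibition), compound 2 gives 0%, the lowest of the three numbers; compound 1 gives 42% and compound 3 gives 66%, both beyond the scatter above it. Compound 4 `O=[N+]([O-])c1ccccc1N1CCN(CCCOc2ccc3c(c2)CCC3)CC1` is not yet measured; the change from compound 2 is 2-nitrophenyl in place of 3,5-dichlorophenyl on an amine nitrogen in a ring. For the measured compounds named here, the one measured step that bears on this change is the swap of the aryl group on the ring nitrogen, a number 42 percentage points lower from compound 1 to compound 2 (beyond the scatter), which was large. Compound 3 differs from compound 2 in two places, so its value only shows the spread of the series. A large step is therefore expected, and since compound 2 sits at the floor of the read-out, only an upward one can show. Compound 4 is expected to give 30%, in the range 0% to 65%. The expected step is a number 30 percentage points higher from compound 2 to compound 4 (beyond the scatter).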

Compound 4, a percentage reported as inhibition, in the whole organism at one dose (the size of the read-out at that dose, not a potency): 43%
The estimate for compound 4 lay 13 percentage points below the measured number; measured number inside the range.
By their numbers in this assay, from the lowest: compound 2; then compounds 1 and 4 (each within the scatter of the next); then compound 3.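

In this assay, the aryl group on the ring nitrogen need not abolish the effect, with a number 43 percentage points higher from compound 2 to compound 4 (beyond the scatter). Two differently substituted aryl groups read alike here, with a number 1 percentage points higher from compound 1 to compound 4 (within the scatter), so among compounds 1, 2 and 4 only the 3,5-dichlorophenyl of compound 2 stands apart. No measurement on hand explains the separation of these aryl groups.

Open, from the compounds shown here alone, is whether a single chlorine on the phenyl ring reads like 3-fluorophenyl or like 3,5-dichlorophenyl. Also open, going by these compounds, is how 2-nitrophenyl reads on the longer chain of compound 3.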